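The source may report more compounds than this note shows. Statements on the series, on what has been measured and on what is new or still open speak of the compounds shown alone.

Going by the values given here, compound 2, `COc1ccc2c(=O)c(/C=C/C(=O)NCc3cccc(F)c3)coc2c1`, is the only compound in this set with a measured number: in a functional assay (QGY7701 cells, Homo sapiens) for inhibition, read by MTT assay, with a stated time of 48 h (a higher number here means a weaker inhibitor, a lower number a stronger inhibitor), compound 2 gives 28600 nM. Its neighbour compound 1, `COc1ccc2c(=O)c(/C=C/C(=O)Nc3cccc(C)c3)coc2c1`, has no number in this assay; compound 1 gives > 100000 nM, which is a limit of the assay rather than a measured value. Among the compounds with values here, the one measured step, an at least 3.4-fold lower number from compound 1 to compound 2 (0.54 log units; beyond the scatter), swaps the group on the amide nitrogen and brings compound 2 onto the measurable side, the only evidence being (the limit of > 100000 nM in this assay, at which 1 of the 2 values shown sits). Compound 3, `COc1ccc(CNC(=O)/C=C/c2coc3cc(OC)ccc3c2=O)cc1`, keeps the core and the benzyl-type attachment of compound 2 but changes the ring on it: 4-methoxyphenyl in place of 3-fluorophenyl on a saturated chain carbon bound to an amide-type nitrogen. This is a smaller change than the measured step, which exchanged a phenyl-type group for a benzyl-type group and shows only how far compound 2 sits from the limit; nothing measured separates one ring substituent from another. The expected step from compound 2 to compound 3 in this assay is therefore small, a 1.0-fold higher number from compound 2 to compound 3 (0.02 log units; within the scatter), in no direction beyond the scatter. Compound 3 is estimated at 30000 nM, with a range from 10000 nM to 100000 nM.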

Compound 3, half-maximal inhibitory concentration: 15700 nM
Compound 3: middle estimate off by 1.9-fold (0.28 log units), on the high side; measured number inside the range.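

On the saturated chain carbon bound to an amide-type nitrogen, 3-fluorophenyl and 4-methoxyphenyl cannot be told apart in this assay: the comparison gives a 1.8-fold lower number from compound 2 to compound 3 (0.26 log units; within the scatter). Going by these compounds alone, a second benzyl-type group now also gives a measured number, with an at least 6.3-fold lower number from compound 1 to compound 3 (0.80 log units; beyond the scatter), so measurable inhibition in this small set is no longer tied to the single 3-fluorobenzyl group of compound 2. That step has only a lower bound for its size, since compound 1 rests on a limit of the assay: the limit of > 100000 nM in this assay, at which 1 of the 3 values shown sits.

Compound 2 and compound 3 differ in both the ring substituent and where it sits, so 4-fluorobenzyl or 3-methoxybenzyl groups would be needed to separate these two features, and 3-methylbenzyl would show whether the extra chain carbon alone accounts for the step away from compound 1. Also open, going by these compounds, is how an unsubstituted benzyl group, a longer chain such as 2-phenylethyl, or a ring carrying an amine or a carboxylic acid would compare on the same amide nitrogen.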